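A few compounds are considered here, and "the series" means these few. Any claim that something is new, unique, unknown or untested is made for them only; others in the source may bear on it.

Compound 1 `COc1cc(-c2nnc3n2NC(c2ccco2)C(C(=O)c2ccccc2C)S3)cc(OC)c1OC` gives 69900 nM in a functional assay on MCF7 cells (Homo sapiens) for cytotoxicity, read by MTT assay, with a stated time of 48 h; on this read-out higher numbers stand for weaker inhibition and lower numbers for stronger inhibition.
Compound 2 `COc1cc(-c2nnc3n2NC(c2ccco2)C(C(=O)c2ccc(C)cc2)S3)cc(OC)c1OC` reaches only the limit of this assay, > 100000 nM.
Compound 3 `COc1ccc(C(=O)C2Sc3nnc(-c4cc(OC)c(OC)c(OC)c4)n3NC2c2ccco2)cc1` likewise reaches only the limit of this assay, > 100000 nM.

Among the measured compounds shown here, compound 1 stands as the sole actual number in this set; the other two results are limits rather than numbers, as the limit of > 100000 nM in this assay, at which 2 of the 3 values shown sit, shows. Compound 4 `COc1cc(-c2nnc3n2NC(c2ccco2)C(C(=O)c2ccc(F)c(F)c2)S3)cc(OC)c1OC` is not yet measured. It differs from compound 1 by 3,4-difluorophenyl in place of 2-methylphenyl on a carbonyl carbon.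

For the measured compounds named here, two measured steps bear on this change, since each also swaps the 2-methylphenyl on the carbonyl carbon for another phenyl ring: an at least 1.4-fold higher number from compound 1 to compound 2 (0.15 log units; that floor lies within the scatter) and an at least 1.4-fold higher number from compound 1 to compound 3 (0.15 log units; that floor lies within the scatter). From the compounds shown here alone, both end at the limit, so their true size is unknown, and both floors lie within the scatter. Going by the values given here, no step here separates a ring change on that carbonyl carbon from mere noise, and nothing points toward a stronger inhibition.

Compound 4 is therefore expected to land near or beyond the limit, with a step of a 1.6-fold higher number from compound 1 to compound 4 (0.20 log units; within the scatter) from compound 1. The estimate for compound 4 is 110000 nM, between 45000 nM and 300000 nM.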

Compound 4, half-maximal inhibitory concentration: 73200 nM
Estimate against measurement, compound 4: 1.5-fold (0.18 log units) above; low and high end bracket the measured number.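

Among the compounds shown here, compound 4 gives a real number rather than a limit, so a ring change on this carbonyl carbon can be sized for the first time in this assay: a 1.0-fold higher number from compound 1 to compound 4 (0.02 log units; within the scatter). The 3,4-difluorophenyl and 2-methylphenyl rings therefore cannot be told apart here, and the comparisons with the other two rings, an at least 1.3-fold lower number from compound 3 to compound 4 (0.13 log units; that floor lies within the scatter) and an at least 1.3-fold lower number from compound 2 to compound 4 (0.13 log units; that floor lies within the scatter), establish no order among the rings either. Those two steps give only floors because compound 2 and compound 3 each sit at a limit, not at a number: the limit of > 100000 nM in this assay, at which 2 of the 4 values shown sit.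

Every compound shown carries a phenyl ring on this carbonyl carbon, so it remains open whether an amine, a carboxylic acid or a longer alkyl chain there would shift the number beyond the scatter. From the compounds shown here alone, all four also share the same core, so the effect of changes there remains open too.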